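Hydroxy for Fluoro on the Benzylidene Ring

The source may hold more compounds than are shown below. What is called first, only, known or untested is meant among the compounds shown, and "the series" means these compounds.

Measured compounds:
Compound 1 `COc1ccc(/C=C2/C(=O)N(c3c(Cl)cccc3Cl)c3ccccc32)cc1`; in a functional assay on SW-620 cells (Homo sapiens) for cytotoxicity, read by MTT assay, with a stated time of 3 days (a higher number here means that more compound is needed for the effect, a lower number that less compound is needed), compound 1 reaches only a limit, > 100 ug/mL.
Compound 2 `O=C1/C(=C/c2ccc(F)cc2)c2ccccc2N1c1c(Cl)cccc1Cl`; in this assay compound 2 gives 5 ug/mL.

Compound 2 thus holds the only number shown in this assay, the other value being a limit. Compound 3 `O=C1/C(=C/c2ccc(O)cc2)c2ccccc2N1c1c(Cl)cccc1Cl` differs from compound 2 in one place: hydroxy in place of fluoro on an aromatic carbon. Going by the values given here, the one measured step that touches this position is an at least 20-fold lower number from compound 1 to compound 2 (1.30 log units; beyond the scatter), a large step that starts from the limit of > 100 ug/mL in this assay, at which 1 of the 2 values shown sits. That step took an oxygen-bearing methoxy off the same carbon and put a fluoro in its place, and the number fell markedly. The change to compound 3 goes the other way, taking the fluoro off again and putting an oxygen-bearing hydroxy on. Hydroxy is not methoxy, and no measured pair shows what a hydroxy does here, so the direction is taken from the one step that exists. The expected step is a 6.0-fold higher number from compound 2 to compound 3 (0.78 log units; beyond the scatter), upward in number. For compound 3 the estimate is 30 ug/mL, with a range from 5 ug/mL to 150 ug/mL.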

Compound 3, concentration for half-maximal effect: 50 ug/mL
The estimate for compound 3 lay 1.7-fold (0.22 log units) below the measured number, within the range that was stated.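

In this assay, going by these compounds alone, the change from 4-fluorophenyl to 4-hydroxyphenyl gives a 10-fold higher number from compound 2 to compound 3 (1.00 log units; beyond the scatter), the first direct reading of a hydroxy on this aromatic carbon, and it shows that the number rises when fluoro gives way to this group as well as to methoxy. Compound 3 shares with compound 1 an oxygen on this carbon, and both carry a higher number than compound 2, while removing the methyl from that oxygen gives an at least 2.0-fold lower number from compound 1 to compound 3 (0.30 log units; that floor lies within the scatter). Compound 1 stands at a limit, not a number, so that step is only a floor and hydroxy cannot be placed in order against methoxy: the limit of > 100 ug/mL in this assay, at which 1 of the 3 values shown sits.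

The compounds shown carry only fluoro, hydroxy and methoxy on this carbon, so it stays open how an amine, a chloro or a plain hydrogen there would compare with them. On these data alone, it also stays open whether the gap between fluoro and hydroxy would hold with changes elsewhere on the shared core, since a single pair speaks for this one setting only.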